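Cytotoxicity notes: azetidine replacement for the pyrrolidine amide

The source may report more compounds than this note shows. Statements on the series, on what has been measured and on what is new or still open speak of the compounds shown alone.

Two members of this series have a measured number in an ADME assay on MT4 cells (Homo sapiens) for cytotoxicity, read by MTT assay, with a stated time of 5 days; on this read-out higher numbers stand for lower toxicity in this test and lower numbers for higher toxicity in this test. Compound 1 `Cc1cc(C)cc(S(=O)(=O)c2c(C(=O)N[C@@H]3CCN(Cc4cccnc4)C3)[nH]c3ccc(Cl)cc23)c1` gives 36500 nM in this assay, the higher of the two numbers. Compound 2 `Cc1cc(C)cc(S(=O)(=O)c2c(C(=O)N[C@H]3CCN(Cc4n[nH]c(=O)n4C)C3)[nH]c3ccc(Cl)cc23)c1` gives 21500 nM in this assay, and the gap between compound 1 and compound 2 lies within the scatter, so the two read as alike.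

Compound 3 `Cc1cc(C)cc(S(=O)(=O)c2c(C(=O)NC3CN(Cc4ccccc4F)C3)[nH]c3ccc(Cl)cc23)c1` has not been tested in this assay. Relative to compound 1 the change is 1-(2-fluorobenzyl)azetidin-3-yl in place of 1-((pyridin-3-yl)methyl)pyrrolidin-3-yl on an amide-type nitrogen. Among the compounds with values here, no pair of measured compounds isolates a change of this kind, so there is no measured step to lean on. The expectation is a step from compound 1 to compound 3 of a 1.2-fold lower number from compound 1 to compound 3 (0.09 log units; within the scatter), that is, none beyond the scatter, because both compound 1 at 36500 nM and compound 2 at 21500 nM sit close together despite their different amide substituents. Compound 3 is therefore estimated at 30000 nM in this assay, with a range of 12000 nM to 75000 nM.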

Compound 3, half-maximal cytotoxic concentration: > 238000 nM
Compound 3 ended at the assay's limit; the forecaster's own chance of this, stated with the estimate: 15%; middle value at least 7.9-fold (0.89 log units) away from the limit.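

In this assay, the substituent on the amide-type nitrogen proves able to move the read-out, with an at least 6.5-fold higher number from compound 1 to compound 3 (0.81 log units; beyond the scatter), towards lower toxicity in this test. Compound 3 stands at > 238000 nM, which is a limit of the assay and not a number, so the step is a bound only: the limit of > 238000 nM in this assay, at which 1 of the 3 values shown sits. The earlier compounds shown here showed no gap beyond the scatter, and this step shows that the read-out is not flat at this position, although the four-membered ring and the 2-fluorobenzyl group enter together.

The compounds shown leave open which of these two parts carries the step. A 1-((pyridin-3-yl)methyl)azetidin-3-yl group or a 1-(2-fluorobenzyl)pyrrolidin-3-yl group on the same nitrogen would separate them, and how the 3-position stereocentre of the pyrrolidine bears on the read-out also stays unresolved.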